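Mirror Image of an Amide with Two Shifted Ring Centres

A few compounds are considered here, and "the series" means these few. Any claim that something is new, unique, unknown or untested is made for them only; others in the source may bear on it.

Compound 2 `C[C@@H]1C[C@H]1C(=O)N1CC2CNCC2C1` gives 1700 nM in an assay on SHEP1 cells for agonist activity at Neuronal acetylcholine receptor; alpha4/beta2 (Homo sapiens), read by FLIPR and calcium flux (on this read-out lower numbers stand for an effect already at smaller amounts and higher numbers for an effect only at larger amounts of compound), the lowest of the two numbers seen so far. Compound 1 `C[C@H]1C[C@H]1C(=O)N1CC2CNCC2C1` gives 19000 nM; the step of an 11-fold lower number from compound 1 to compound 2 (1.05 log units; beyond the scatter) rests only on how one ring carbon is drawn (the fact that one of compounds 1 and 2 is drawn with a defined configuration and the other without, at the place where they differ). Compound 3 `C[C@H]1C[C@@H]1C(=O)N1CC2CNCC2C1` differs from compound 2 in the two compounds have the same atoms and bonds; at least one stereo element is drawn with a configuration in one of them and without one in the other: 2 of 4 stereo elements differ; a stereocentre at a saturated ring carbon is drawn R in compound 2 and S in compound 3; a stereocentre at a saturated ring carbon is drawn R in compound 2 and S in compound 3, so it is the mirror image of compound 2 at those two ring carbons. Since redrawing a single centre already moved the number this far, inverting both is expected to push it back upward, by about a 3.5-fold higher number from compound 2 to compound 3 (0.55 log units; beyond the scatter). Compound 3 is therefore expected to give 6000 nM, likely between 1200 nM and 30000 nM.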

Compound 3, half-maximal effective concentration: 5600 nM
Compound 3: the middle estimate sits 1.1-fold (0.03 log units) above what was measured; the measured number falls inside the stated range.
By their numbers in this assay, from the lowest: compound 2; then compound 3; then compound 1.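

The second ring carbon matters as well: in this assay, redrawing that centre alone gives a 3.4-fold lower number from compound 1 to compound 3 (0.53 log units; beyond the scatter). Mirror-image forms are not equal here either, with a 3.3-fold higher number from compound 2 to compound 3 (0.52 log units; beyond the scatter), so the number follows the combination of the two centres rather than either centre alone. Redrawing either single centre of compound 1 lowers the number.

As far as these compounds go, the mirror image of compound 1 remains open. So does whether a longer chain or an amine in place of the methyl group would keep this dependence on configuration.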